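Swapping 4-Fluorophenyl for 2-Chlorophenyl in Compound 4

A few compounds are considered here, and "the series" means these few. Any claim that something is new, unique, unknown or untested is made for them only; others in the source may bear on it.

Of the compounds shown here, three have been tested in a functional assay on HL-60 cells (Homo sapiens) for inhibition, read by MTT assay, with a stated time of 72 h; on this read-out lower numbers stand for stronger inhibition and higher numbers for weaker inhibition. Compound 1 `Cc1ccc(C)c(N2CCN(C(=O)c3oc(C)nc3-c3ccc(F)cc3)CC2)c1` gives 358 nM. Compound 2 `Cc1ccc(C)c(N2CCN(C(=O)c3oc(C)nc3-c3ccccc3Cl)CC2)c1` reaches only a limit of the assay, > 1000 nM; this is the limit (the limit of > 1000 nM in this assay, at which 1 of the 3 values shown sits). The change from compound 1 to compound 2 is 2-chlorophenyl in place of 4-fluorophenyl on an aromatic carbon, and it brought an at least 2.7-fold higher number from compound 1 to compound 2 (0.44 log units; beyond the scatter). Compound 3 `CCc1nc(-c2ccc(F)cc2)c(C(=O)N2CCN(c3cccc(Cl)c3)CC2)o1` gives 169 nM, the lower number of the two measured figures, with compound 1 standing a step above it. The difference between the core of compound 3 and the core of compound 1 is not broken down here.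

Compound 4 `CCc1nc(-c2ccccc2Cl)c(C(=O)N2CCN(c3cccc(Cl)c3)CC2)o1` has not yet been measured. It differs from compound 3 by 2-chlorophenyl in place of 4-fluorophenyl on an aromatic carbon. This is the same kind of change as that from compound 1 to compound 2, although the surroundings differ: in compound 3 the ring atom two ring bonds away bears an ethyl group, in compound 1 a methyl group. For compound 4 a step of a 4.1-fold higher number from compound 3 to compound 4 (0.62 log units; beyond the scatter) is expected, resting on compound 1, whose change to compound 2 gave an at least 2.7-fold higher number from compound 1 to compound 2 (0.44 log units; beyond the scatter). Compound 4 is therefore estimated at 700 nM, most likely between 300 nM and 2000 nM.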

Compound 4, half-maximal inhibitory concentration: 98.9 nM
For compound 4 the middle estimate is 7.1-fold (0.85 log units) above the measured one; the measured number lies below the stated range.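

In this assay the swap of 4-fluorophenyl for 2-chlorophenyl gave a 1.7-fold lower number from compound 3 to compound 4 (0.23 log units; within the scatter), so it made no clear difference on this core, and its effect did not carry over from the core of compound 1: the same change on two cores in this assay, an at least 2.7-fold higher number (0.44 log units; beyond the scatter) from compound 1 to compound 2 and a 1.7-fold lower number (0.23 log units; within the scatter) from compound 3 to compound 4, at least 4.7-fold (0.67 log units) apart, beyond the scatter of two such steps. The value of compound 2, > 1000 nM, is a limit of the assay and not a number. These results do not show which difference between the cores matters: the cores differ in more than one place, and a single pair of steps gives no rule for any further core.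

The compounds shown leave open whether the ethyl group alone decides the outcome, as no pair here differs only by ethyl against methyl at that ring atom. They also leave open how a longer chain such as propyl at the same ring atom, or an amine on the phenyl ring, would behave with either of the two phenyl groups.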